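A few compounds are considered here, and "the series" means these few. Any claim that something is new, unique, unknown or untested is made for them only; others in the source may bear on it.

Compound 1 `O=C(Nc1ccc(-n2ncc3c(Br)cccc32)cc1)Nc1ccc(Cl)c(C(F)(F)F)c1` — in a functional assay on OS-RC-2 cells (Homo sapiens) for cytotoxicity, read by MTT assay, with a stated time of 72 h (on this read-out lower numbers stand for stronger inhibition and higher numbers for weaker inhibition), compound 1 gives 9900 nM.
Compound 2 `O=C(Nc1ccc(-n2ncc3c(C(F)(F)F)cccc32)cc1)Nc1ccc(C(F)(F)F)cc1` — in this assay compound 2 gives 4000 nM.

Of the two measured compounds, compound 1 stands at the higher number, and the gap between compound 1 and compound 2 lies beyond the scatter, so compound 1 is the weaker of the pair in this assay. Compound 3 `O=C(Nc1ccc(-n2ncc3ccncc32)cc1)Nc1ccc(Cl)c(C(F)(F)F)c1` is not yet measured. It differs from compound 1 in one place: a group of 9 heavy atoms (6 carbon, 3 nitrogen; one five-membered aromatic ring with 2 hetero atoms, one six-membered aromatic ring with 1 hetero atom) in place of a group of 10 heavy atoms (7 carbon, 2 nitrogen, 1 bromine; one five-membered aromatic ring with 2 hetero atoms, one six-membered aromatic ring of carbon only), on an aromatic carbon. The change sits on an aromatic carbon of a six-membered aromatic ring of carbon only, para to a large group, while the urea linkage and the other aryl ring of compound 1 are kept.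

Within the data shown here, no measured pair in this set isolates this exchange, so there is no step to lean on. The expectation for compound 3 is a modest move toward weaker inhibition, with a step estimated as a 1.5-fold higher number from compound 1 to compound 3 (0.18 log units; within the scatter), though a result within the scatter of compound 1 is also plausible. Compound 3 is expected to give about 15000 nM in this assay, with a range from 5000 nM to 45000 nM.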

Compound 3, half-maximal inhibitory concentration: > 32000 nM
Compound 3 was reported as a limit; the forecaster's own chance of this, stated with the estimate: 20%; middle value at least 2.1-fold (0.32 log units) away from the limit.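

Exchanging the 4-bromo-1H-indazol-1-yl group of compound 1 for the group with a hetero atom in its six-membered aromatic ring, on an aromatic carbon para to a large group, gives an at least 3.2-fold higher number from compound 1 to compound 3 (0.50 log units; beyond the scatter) in this assay. Among these compounds, this is the first change in the set that can be read in one place, with the urea linkage and the other aryl ring kept, and it shows that this position does not tolerate the exchange without a loss of inhibition beyond the scatter. The value of compound 3 is a limit of the assay and not a number, so this step gives only a lower bound on the size of the loss: the limit of > 32000 nM in this assay, at which 1 of the 3 values shown sits.

The exchange removes the bromine and adds the ring nitrogen together, and the compounds shown leave open which of the two accounts for the step. They also leave open how a methoxy group or an amine carried on the six-membered ring of the group would read in this assay, and whether any group there could bring the number below that of compound 1.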